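A few compounds are considered here, and "the series" means these few. Any claim that something is new, unique, unknown or untested is made for them only; others in the source may bear on it.

Working notes on the series in a functional assay on A549 cells (Homo sapiens) for cytotoxicity, read by resazurin assay, with a stated time of 72 h; on this read-out lower numbers stand for stronger inhibition and higher numbers for weaker inhibition: compound 1 `N#Cc1cc(-c2ccccc2)n(-c2ccncc2)c1N` gives 10700 nM, compound 2 `N#Cc1cc(-c2ccccc2)n(-c2ccc(Br)cc2)c1N` gives 4600 nM, and compound 3 `Nc1c(-c2nc3ccccc3[nH]2)cc(-c2ccccc2)n1-c1ccncc1` gives 1100 nM, the lowest of the three numbers. The next compound is compound 4 `Nc1c(-c2nc3ccccc3[nH]2)cc(-c2ccccc2)n1Cc1nc2ccccc2[nH]1`, which carries (1H-benzimidazol-2-yl)methyl in place of pyridin-4-yl on the aromatic nitrogen of compound 3: (1H-benzimidazol-2-yl)methyl in place of pyridin-4-yl on an aromatic nitrogen.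

Within the data shown here, two measured steps bear on this change. Among the measured compounds shown here, the only change measured on that nitrogen is a 2.3-fold lower number from compound 1 to compound 2 (0.37 log units; beyond the scatter), a modest step, but it introduces 4-bromophenyl and was made with the nitrile still present. The other is a 9.7-fold lower number from compound 1 to compound 3 (0.99 log units; beyond the scatter), also modest, which shows a lower number on introducing 1H-benzimidazol-2-yl, although at an aromatic carbon rather than on the nitrogen. Neither step transfers directly, so only a slight lean towards lower numbers is warranted in this assay, with no shift beyond the scatter firmly expected. The expected size is a 1.4-fold lower number from compound 3 to compound 4 (0.14 log units; within the scatter). The estimate for compound 4 is 800 nM, with an expected range of 250 nM to 2800 nM.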

Compound 4, half-maximal inhibitory concentration: 5100 nM
Beside the measured number, compound 4's estimate is 6.4-fold (0.80 log units) below it; measured number outside the range, above it.
By their numbers in this assay, from the lowest: compound 3; then compounds 2 and 4 (each within the scatter of the next); then compound 1.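

In this assay, among these compounds, the aromatic nitrogen of the shared core stays sensitive to its substituent with 1H-benzimidazol-2-yl held on the ring carbon: a 4.6-fold higher number from compound 3 to compound 4 (0.67 log units; beyond the scatter) is beyond the scatter and runs opposite to the only other change on that nitrogen, a 2.3-fold lower number from compound 1 to compound 2 (0.37 log units; beyond the scatter) in the nitrile series. The (1H-benzimidazol-2-yl)methyl group on the nitrogen therefore does not repeat the direction of a 9.7-fold lower number from compound 1 to compound 3 (0.99 log units; beyond the scatter), where 1H-benzimidazol-2-yl enters on the aromatic carbon. No measurement at hand accounts for the higher number of compound 4.

Going by these compounds, whether the step tracks the methyl link or the benzimidazole part remains open. Also open, on these data alone, is how a benzyl group, an ethyl chain or an aminoethyl chain on that nitrogen would read with 1H-benzimidazol-2-yl kept on the carbon.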